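The compounds below may be only part of what the source reports. "The series", "measured", "known", "first", "only" and "open" are said of these compounds alone.

In a functional assay on A549 cells (Homo sapiens) for antiproliferative activity, read by MTT assay, with a stated time of 72 h (a higher number here means a weaker inhibitor, a lower number a stronger inhibitor), compound 1 `O=C(N/N=C/c1ccc(Br)cc1)Nc1ccc(Oc2ccnc3[nH]ccc23)cc1` gives 640 nM. Compound 2 `O=C(N/N=C/c1ccc([N+](=O)[O-])cc1)Nc1ccc(Oc2ccnc3[nH]ccc23)cc1` gives 2100 nM, the higher of the two numbers, which makes it the weaker inhibitor of this pair. Compound 3 `O=C(N/N=C/c1ccc(O)cc1)Nc1ccc(Oc2ccnc3[nH]ccc23)cc1` has not yet been measured. It carries hydroxy in place of nitro on an aromatic carbon, para to a large group: hydroxy in place of nitro on an aromatic carbon. Among the compounds with values here, only one measured step bears on this change, the swap of bromo for nitro, which gave a 3.3-fold higher number from compound 1 to compound 2 (0.52 log units; beyond the scatter). That step is modest but beyond the scatter. Within the data shown here, no compound with hydroxy has a measured value yet, so the direction is uncertain. Since nitro gave the higher number of the pair, a step toward a lower number, no larger than that one, is expected in this assay. The estimate for compound 3 is 1000 nM, with an expected range of 300 nM to 3300 nM. This estimate means an expected 2.1-fold lower number from compound 2 to compound 3 (0.32 log units; beyond the scatter).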

Compound 3, half-maximal inhibitory concentration: 1910 nM
The estimate for compound 3 lay 1.9-fold (0.28 log units) below the measured number; measured number inside the range.
By their numbers in this assay, from the lowest: compound 1; then compounds 3 and 2 (each within the scatter of the next).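

In this assay, hydroxy in place of nitro gives a 1.1-fold lower number from compound 2 to compound 3 (0.04 log units; within the scatter), so at this position the two groups cannot be told apart, even though hydroxy brings a hydrogen-bond donor that nitro lacks. Hydroxy in place of bromo gives a 3.0-fold higher number from compound 1 to compound 3 (0.47 log units; beyond the scatter), which shows that compound 1 now stands apart from two other compounds, not just one, and that the bromo compound has the lowest number of the three. Nothing measured here gives a reason for this pattern.

The compounds shown leave open whether the lower number belongs to bromo alone or extends to other halogens such as chloro or fluoro. They also leave open how an amine or a carboxylic acid at this same place would compare.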